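Cyano to Methoxy on a Shared Core

The source may hold more compounds than are shown below. What is called first, only, known or untested is meant among the compounds shown, and "the series" means these compounds.

Of the compounds shown here, three built on one core have been tested in an assay on HEK293-TREx cells for antagonist activity at transient receptor potential cation channel subfamily A member 1 (Homo sapiens), read by fluorescence and calcium flux, with a stated time of 72 h; on this read-out lower numbers stand for stronger inhibition and higher numbers for weaker inhibition. Compound 1 `Fc1ccc(Oc2ncnc3[nH]ccc23)c(F)c1` carries two fluorine atoms on the outer ring and gives 710 nM. Compound 2 `Cc1ccccc1Oc1ncnc2[nH]ccc12`, with a methyl group instead, is reported only as a limit of the assay, > 32000 nM. Compound 3 `N#Cc1ccc(Oc2ncnc3[nH]ccc23)cc1` bears a cyano group and is also reported only as a limit, > 32000 nM. For the measured compounds named here, compound 3 thus stands at the ceiling of what this assay reports, while compound 1 is the only compound with an actual number, as the evidence shows: the limit of > 32000 nM in this assay, at which 2 of the 3 values shown sit.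

Compound 4 `COc1ccc(Oc2ncnc3[nH]ccc23)cc1` differs from compound 3 in one place: methoxy in place of cyano on an aromatic carbon. Among the measured compounds no pair differs in exactly one place, so no measured step can be carried over. Neither the methyl compound nor the cyano compound produced a measurable value, and only the fluorine-bearing compound did; nothing here shows a methoxy group pulling a compound off the limit. The expected step is therefore small or absent beyond the scatter, with only a modest chance of a gain: an at least 1.6-fold lower number from compound 3 to compound 4 (0.20 log units; that floor lies within the scatter). For compound 4 the estimated value in this assay is 20000 nM, within a range from 3000 nM to 60000 nM, and a limit may well be reported again.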

Compound 4, half-maximal inhibitory concentration: > 32000 nM
Compound 4 ended at the assay's limit (the forecaster's own chance of this, stated with the estimate: 60%); middle value at least 1.6-fold (0.20 log units) from the limit.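

Compound 3 and compound 4 both stand at a limit rather than at a real number, so no step from one to the other can be read: the limit of > 32000 nM in this assay, at which 3 of the 4 values shown sit.

The compounds shown leave open whether methoxy in place of cyano changes inhibition at all, and which other groups on the shared core would give a measurable number, as compound 1 does at 710 nM.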